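The source may hold more compounds than are shown below. What is called first, only, known or untested is meant among the compounds shown, and "the series" means these compounds.

Measured compounds: compound 1 `CO/N=C(\C)COc1ccc2oc(-c3ccccc3)cc(=O)c2c1` gives 800000 nM; compound 2 `COc1ccc(/C(COc2ccc3oc(-c4ccccc4)cc(=O)c3c2)=N\O)cc1` gives 800000 nM; compound 3 `CO/N=C(/COc1ccc2oc(-c3ccccc3)cc(=O)c2c1)c1ccc(F)cc1` gives 7910000 nM, all in a functional assay on SK-HEP1 cells (Homo sapiens) for antiproliferative activity; a lower number here means a stronger inhibitor of growth, a higher number a weaker inhibitor of growth.

Compound 3 stands highest of the three, the weakest inhibitor of growth on this assay. Compound 4 `CO/N=C(/COc1ccc2oc(-c3ccccc3)cc(=O)c2c1)c1ccc(OC)cc1` differs from compound 3 by methoxy in place of fluoro on an aromatic carbon. Among the measured compounds shown here, no measured step matches this change. For the measured compounds named here, the only measured step, a 9.9-fold higher number from compound 1 to compound 3 (1.00 log units; beyond the scatter), exchanges methyl for 4-fluorophenyl and so does not bear on it. Compound 2, which also carries a methoxy on its aryl ring, sits well below compound 3, but it differs in more than one place, so its value gives only a loose hint. The expected step is a 2.6-fold lower number from compound 3 to compound 4 (0.42 log units; beyond the scatter) for compound 4, with wide uncertainty. Compound 4 is estimated at 3000000 nM, between 700000 nM and 12000000 nM.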

Compound 4, concentration for 50% growth inhibition: 2000000 nM
Estimate against measurement, compound 4: 1.5-fold (0.18 log units) above; low and high end bracket the measured number.
By their numbers in this assay, from the lowest: compounds 1 and 2 (each within the scatter of the next); then compound 4; then compound 3.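

In this assay this ring position responds to what sits on it: there is a 4.0-fold lower number from compound 3 to compound 4 (0.60 log units; beyond the scatter) with methoxy in place of fluoro. Methyl in place of hydrogen on an oxygen gives a 2.5-fold higher number from compound 2 to compound 4 (0.40 log units; beyond the scatter) and, with 4-methoxyphenyl in place of methyl on the carbon with a double bond to nitrogen, there is a 2.5-fold higher number from compound 1 to compound 4 (0.40 log units; beyond the scatter) so both aryl versions, compound 3 and compound 4, remain weaker inhibitors of growth than compound 1. No supporting measurement explains these shifts. Open, going by these compounds, is how an amine or a carboxylic acid on this ring position, or a longer chain on the oxygen, would behave.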